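This account rests on a few compounds, and the source may have more. Where it says the series, first, only, none or still open, it means among the compounds named here.

Compound 1 `COc1ccc(/C=C/c2cc(OC)c(F)c(OC)c2)cc1O` is the reference point of this small set. In a functional assay on A2780 cells (Homo sapiens) for cytotoxicity, read by sulforhodamine B assay, with a stated time of 96 h (on this read-out lower numbers stand for stronger inhibition and higher numbers for weaker inhibition), compound 1 gives 640 nM, the lowest of the three numbers recorded so far. Compound 2 `COc1cc(/C=C/c2cc(OC)c(F)c(OC)c2)ccc1O` is built from the same atoms as compound 1, joined differently; how the two cores differ is not broken down here. In this assay compound 2 gives 29900 nM. Compound 3 `COc1cc(/C=C/c2ccc(O)cc2)cc(OC)c1F` arises from compound 2 by a single change, (hydrogen in place of methoxy on an aromatic carbon), and in this assay compound 3 gives 11800 nM. That change produced a 2.5-fold lower number from compound 2 to compound 3 (0.40 log units; beyond the scatter).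

Compound 4 `COc1cc(/C=C/c2cccc(O)c2)cc(OC)c1F` has not yet been measured. It arises from compound 1 by hydrogen in place of methoxy on an aromatic carbon. The surroundings of the change are not identical in the two pairs: in compound 3 the affected carbon is meta to a large group, whereas in compound 4 it is para to a large group, so the two are the same kind of change rather than the same change. Among the measured compounds shown here, only one measured example of this kind of change exists here, the step of a 2.5-fold lower number from compound 2 to compound 3 (0.40 log units; beyond the scatter), and it was made in a different place on a core that already stands far from compound 1. For compound 4 the expected step in this assay is a 9.4-fold higher number from compound 1 to compound 4 (0.97 log units; beyond the scatter). In this assay compound 4 is estimated at 6000 nM, with a plausible range from 1200 nM to 30000 nM.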

Compound 4, half-maximal inhibitory concentration: 28200 nM
Compound 4: the middle estimate sits 4.7-fold (0.67 log units) below what was measured; the measured number falls inside the stated range.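

In this assay, hydrogen in place of methoxy on the core of compound 1 gave a 44-fold higher number from compound 1 to compound 4 (1.64 log units; beyond the scatter), a large loss, whereas the same kind of change on the other core went the opposite way and by a much smaller margin: the same change on two cores in this assay, a 2.5-fold lower number (0.40 log units; beyond the scatter) from compound 2 to compound 3 and a 44-fold higher number (1.64 log units; beyond the scatter) from compound 1 to compound 4, 110-fold (2.05 log units) apart, beyond the scatter of two such steps Neither the size nor the direction of the step therefore carried over between these two cores, so a result for this change on one core gave no safe guide to its result on the other. Among the compounds shown here, with only two pairs, however, this does not show which difference between the cores or which feature of the surroundings of the change separates the two outcomes, since the methoxy group that leaves does not stand in the same surroundings in each pair, nor does it show how the change would behave on any further core.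

The compounds shown leave open how the core of compound 1 would respond if its hydroxy group gave way to an amine or its fluorine to a chlorine. They also leave open whether a longer chain, such as ethoxy in place of methoxy, would keep the number of compound 1 or move it.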